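Adding a Sulfamoyl Group to the Stronger of Two Compounds

The compounds below may be only part of what the source reports. "The series", "measured", "known", "first", "only" and "open" are said of these compounds alone.

Going by the values given here, the two compounds measured so far share a core carrying an acetic acid side chain. Compound 1 `O=C(O)Cc1sc(NCc2ccccc2)nc1-c1ccc(Cl)cc1` bears a benzylamino group and a chlorophenyl ring; in an in vitro assay on HEK385-7 cells for displacement of a labelled ligand from prostaglandin D2 receptor 2 (Homo sapiens) (a lower number here means a stronger inhibitor, a higher number a weaker inhibitor), compound 1 gives 440 nM. Compound 2 `O=C(O)Cc1sc(C(c2ccc(F)cc2)c2ccc(F)cc2)nc1-c1ccccc1` instead carries a bis(4-fluorophenyl)methyl group and an unsubstituted phenyl ring; in this assay compound 2 gives 16 nM. Compound 2 thus stands at the lower of the two numbers, and the gap to compound 1 lies well beyond the usual scatter, so compound 2 is the stronger inhibitor of the pair.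

Compound 3 `NS(=O)(=O)c1cccc(-c2nc(C(c3ccc(F)cc3)c3ccc(F)cc3)sc2CC(=O)O)c1` keeps everything in compound 2 and changes one place: sulfamoyl in place of hydrogen on an aromatic carbon. Among the compounds with values here, no measured pair shows what such an addition does, so the direction of the step is open. Given that compound 2 gives 16 nM in this assay, the step from compound 2 to compound 3 is expected to be small, a 1.6-fold higher number from compound 2 to compound 3 (0.19 log units; within the scatter), most likely within the scatter or a slight weakening. Compound 3 is therefore expected to give about 25 nM in this assay, within a range from 6 nM to 100 nM.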

Compound 3, half-maximal inhibitory concentration: 140 nM
For compound 3 the middle estimate is 5.6-fold (0.75 log units) below the measured one; measured number above the stated range.
By their numbers in this assay, from the lowest: compound 2; then compound 3; then compound 1.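

In this assay, replacing hydrogen with sulfamoyl on an aromatic carbon, which turns phenyl into 3-sulfamoylphenyl, gives an 8.8-fold higher number from compound 2 to compound 3 (0.94 log units; beyond the scatter). Going by these compounds alone, this is the first single-place change measured, and it shows that this position on the aromatic ring is not indifferent to substitution: adding the sulfamoyl group, with everything else held constant, costs a modest but real loss of inhibition beyond the usual scatter. The data give no measured basis for explaining this loss.

The compounds shown leave open whether the loss belongs to the sulfamoyl group itself or to any addition at this carbon, a question that a methyl group, a chlorine atom, an amine or a carboxylic acid at the same place would help to settle. They also leave open whether sulfamoyl would cost as much on a different carbon of the ring, or on a compound carrying a benzylamino group in place of the bis(4-fluorophenyl)methyl group.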